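A Large Group Gives Way to 2-Oxooxolan-3-yl

The source may report more compounds than this note shows. Statements on the series, on what has been measured and on what is new or still open speak of the compounds shown alone.

In a physicochemical assay for lipophilicity, read by HPLC, at pH 7.5 (a higher number here means a more lipophilic compound, a lower number a more polar compound), compound 3 `CCOc1ccccc1-c1ccc(-c2nc3cnccc3c(NC(CC)CNS(=O)(=O)C3CC3)c2C#N)cc1` gives 3.6 and stands level with compound 1 `CCCCC(Nc1c(C#N)c(-c2ccc(-c3ccccc3OCC)cc2)nc2cnccc12)C(N)=O` at 3.6 on the digits shown, while compound 2 `CCOc1ccccc1-c1ccc(-c2nc3cnccc3c(NC(COC)C(N)=O)c2C#N)cc1` gives 2.8 and lies lower than both.

Compound 4 `CCOc1ccccc1-c1ccc(-c2nc3cnccc3c(N[C@@H]3CCOC3=O)c2C#N)cc1` has not been measured yet. It differs from compound 3 by a group of 6 heavy atoms (4 carbon, 2 oxygen; one five-membered non-aromatic ring with 1 hetero atom) in place of a group of 11 heavy atoms (7 carbon, 1 nitrogen, 2 oxygen, 1 sulfur; one three-membered non-aromatic ring of carbon only), on a nitrogen on an aromatic ring and the entering group is named 2-oxooxolan-3-yl.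

Two measured steps also change the group on this same nitrogen. One shows no change at the digits printed from compound 1 to compound 3 (within the scatter) and the other shows a number 0.80 log units higher from compound 2 to compound 3 (beyond the scatter) so swaps here have ranged from nothing to modest. A smaller edit within that group, exchanging propyl for methoxy, gives a number 0.80 log units lower from compound 1 to compound 2 (beyond the scatter) as well.

Among the measured compounds shown here, the entering group appears in no measured compound, so this evidence is indirect. A fall smaller than those modest steps is expected, and the estimated size is a number 0.50 log units lower from compound 3 to compound 4 (beyond the scatter) for now. In this assay the estimate for compound 4 is 3.1 with a range from 2.6 to 3.6 as the expected span.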

Compound 4, distribution coefficient: 2.7
Estimate against measurement, compound 4: 0.40 log units above, and the stated range covers the measured number.
By their numbers in this assay, from the lowest: compounds 4 and 2 (each within the scatter of the next); then compounds 1 and 3 (each within the scatter of the next).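

In this assay, placing 2-oxooxolan-3-yl on the nitrogen on an aromatic ring gives a clear drop from both groups at the high end (a number 0.90 log units lower from compound 3 to compound 4 (beyond the scatter); a number 0.90 log units lower from compound 1 to compound 4 (beyond the scatter)). Against 1-carbamoyl-2-methoxyethyl the same swap gives no real difference (a number 0.10 log units lower from compound 2 to compound 4 (within the scatter)), so a closed ring without a hydrogen-bond donor and an open chain carrying carbamoyl read alike at this position. No measurement shown explains why these numbers fall as they do.

The compounds shown leave open how the number would respond if a carboxylic acid or an amine replaced the ring, or if a lactam with nitrogen in place of the ring oxygen did. They also leave open whether the mirror-image form of 2-oxooxolan-3-yl would read the same.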